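This account rests on a few compounds, and the source may have more. Where it says the series, first, only, none or still open, it means among the compounds named here.

Measured so far:
Compound 1, `O=c1nc(N2CCC3(CCN(Cc4ccccc4)C3)CC2)sc2c([N+](=O)[O-])cc(C(F)(F)F)cc12`: 289000 nM
Compound 2, `O=c1nc(N2CCC3(CCN(Cc4ccc(C(F)(F)F)cc4)CC3)CC2)sc2c([N+](=O)[O-])cc(C(F)(F)F)cc12`: 145000 nM

In an ADME assay on Vero cells (Chlorocebus sabaeus) for cytotoxicity, read by MTT assay, with a stated time of 72 h (a lower number here means that less compound is tolerated, a higher number that more compound is tolerated), compound 2 gives 145000 nM, and that number lies within the usual scatter of the value of compound 1, so the two cannot be told apart. Compound 3, `O=c1nc(N2CCC3(CCN(Cc4cc(F)cc(F)c4)CC3)CC2)sc2c([N+](=O)[O-])cc(C(F)(F)F)cc12`, has not yet been measured in this assay. Its change from compound 2 is 3,5-difluorophenyl in place of 4-(trifluoromethyl)phenyl on a saturated chain carbon bound to an amine nitrogen in a ring. For the measured compounds named here, no measured pair shows what such a change does here, so compound 3 is expected to give a value near that of compound 2, with the step of a 1.4-fold higher number from compound 2 to compound 3 (0.14 log units; within the scatter) expected to stay within the scatter. The estimate for compound 3 is 200000 nM, ranging from 80000 nM to 500000 nM.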

Compound 3, half-maximal cytotoxic concentration in the Vero assay: 1170000 nM
Beside the measured number, compound 3's estimate is 5.9-fold (0.77 log units) below it; measured number outside the range, above it.
By their numbers in the Vero assay, from the lowest: compounds 2 and 1 (each within the scatter of the next); then compound 3.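

In the Vero assay the swap of 4-(trifluoromethyl)benzyl for 3,5-difluorobenzyl gives an 8.1-fold higher number from compound 2 to compound 3 (0.91 log units; beyond the scatter) and so shows that the group at this place can shift how much compound the cells tolerate. In a physicochemical assay for solubility, read by HPLC, with a stated time of 12 h, at pH 2 (on this read-out lower numbers stand for lower solubility and higher numbers for higher solubility), compound 2 gives 1.24 ug/mL and compound 3 gives 0.67 ug/mL and these values lie within the scatter of each other, so no change can be read there. Nothing at hand gives a reason for the step. Still open, on these data alone, is whether the step follows the loss of trifluoromethyl or the arrival of the two fluorines, and what an amine or a carboxylic acid on the phenyl group would do.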